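Ester side-chain variation and cytotoxicity in a quinolinone series

A few compounds are considered here, and "the series" means these few. Any claim that something is new, unique, unknown or untested is made for them only; others in the source may bear on it.

Measured so far in an ADME assay on HepG2 2.2.15 cells (Homo sapiens) for cytotoxicity; on this read-out higher numbers stand for lower toxicity in this test and lower numbers for higher toxicity in this test:
compound 1 `CCCCCCCC(=O)OCCc1c(-c2ccccc2Cl)c2cc(Cl)ccc2[nH]c1=O` gives 78000 nM
compound 2 `O=C(CCC1CCCCC1)OCCc1c(-c2ccccc2Cl)c2cc(Cl)ccc2[nH]c1=O` gives 160000 nM
compound 3 `O=C(CN1C(=O)c2ccccc2C1=O)OCCc1c(-c2ccccc2Cl)c2cc(Cl)ccc2[nH]c1=O` gives 960000 nM

Compound 1 stands lowest of the three numbers in this assay; its nearest neighbour is compound 2 and its furthest is compound 3. Both changes made to the ester chain of compound 1 have moved the number upward: a 2.1-fold higher number from compound 1 to compound 2 (0.31 log units; beyond the scatter) and a 12-fold higher number from compound 1 to compound 3 (1.09 log units; beyond the scatter), with the step of a 6.0-fold higher number from compound 2 to compound 3 (0.78 log units; beyond the scatter) showing that the ring-bearing group of compound 3 lies well beyond the cyclohexyl change.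

Compound 4 `O=C(COc1ccccc1)OCCc1c(-c2ccccc2Cl)c2cc(Cl)ccc2[nH]c1=O` is not yet measured. It differs from compound 1 as follows: phenoxy in place of hexyl on a saturated chain carbon bound to a carbonyl carbon. The change thus brings in an aromatic ring and one acceptor on the saturated chain carbon bound to the carbonyl carbon, which is the same place where the step from compound 1 to compound 3 acted. The two steps from compound 1 that bear on it are the modest one to compound 2 and the large one to compound 3; phenoxy is smaller than the group entering in compound 3, so a step between those two sizes is expected.

Compound 4 is estimated to give 250000 nM in this assay, within 100000 nM to 700000 nM. This expectation corresponds to a 3.2-fold higher number from compound 1 to compound 4 (0.51 log units; beyond the scatter), an upward step beyond the scatter.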

Compound 4, half-maximal cytotoxic concentration: 81000 nM
The estimate for compound 4 lay 3.1-fold (0.49 log units) above the measured number, and the stated range ends above it.
By their numbers in this assay, from the lowest: compounds 1, 4 and 2 (each within the scatter of the next, the first and the last beyond it); then compound 3.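

In this assay, an aromatic ring and a hydrogen-bond acceptor on the saturated chain carbon bound to a carbonyl carbon do not by themselves set a compound apart: phenoxy in place of hexyl gives a 1.0-fold higher number from compound 1 to compound 4 (0.02 log units; within the scatter) and phenoxy in place of cyclohexylmethyl gives a 2.0-fold lower number from compound 2 to compound 4 (0.30 log units; within the scatter) so compound 4 cannot be told apart from compound 1 or compound 2 at this read-out. The high number of compound 3 is not shared by phenoxy, as a 12-fold lower number from compound 3 to compound 4 (1.07 log units; beyond the scatter) makes clear, and at this place among the four compounds the group of 11 heavy atoms stands alone, so a ring at this place is not enough to give that number. No measurement at hand offers an account of this difference.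

Still open, going by these compounds, is whether an amine or a carboxylic acid on the same saturated chain carbon would come close to compound 3 at 960000 nM in this series or stay with the other three compounds. Also open, on these data alone, is whether benzyl, which keeps the aromatic ring without the ether oxygen, would read like phenoxy in this test.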